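This account rests on a few compounds, and the source may have more. Where it says the series, first, only, none or still open, it means among the compounds named here.

Compound 1 `COc1ccc(-c2nn(-c3ccccc3)cc2C(=O)NCc2cn(Cc3ccc(Cl)cc3)nn2)cc1` gives 26300 nM in a functional assay on MIA PaCa-2 cells (Homo sapiens) for antiproliferative activity, read by sulforhodamine B assay, with a stated time of 48 h; on this read-out higher numbers stand for weaker inhibition of growth and lower numbers for stronger inhibition of growth.
Compound 2 `COc1ccc(-c2nn(-c3ccccc3)cc2C(=O)NCc2cn(Cc3ccc(OC)c(OC)c3)nn2)cc1` gives 16300 nM in this assay.

For the measured compounds named here, compound 2 and compound 1 sit within the usual scatter of each other; the only measured step, a 1.6-fold lower number from compound 1 to compound 2 (0.21 log units; within the scatter), is small. Compound 3 `COc1ccc(-c2nn(-c3ccccc3)cc2C(=O)NCc2cn(Cc3cc(OC)c(OC)c(OC)c3)nn2)cc1` differs from compound 2 by methoxy in place of hydrogen on an aromatic carbon. Going by the values given here, no measured step bears directly on this change, and the one step that is known lay within the scatter, so the expected step for compound 3 in this assay is a 1.3-fold lower number from compound 2 to compound 3 (0.10 log units; within the scatter), not beyond the scatter. Compound 3 is therefore estimated at 13000 nM, with a range from 5000 nM to 32000 nM.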

Compound 3, concentration for 50% growth inhibition: 31600 nM
Compound 3: the middle estimate sits 2.4-fold (0.39 log units) below what was measured; the range from low to high includes it.
By their numbers in this assay, from the lowest: compounds 2, 1 and 3 (each within the scatter of the next).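

In this assay, methoxy in place of hydrogen, ortho to a methoxy group, gives a 1.9-fold higher number from compound 2 to compound 3 (0.29 log units; within the scatter) and so does not separate the 3,4,5-trimethoxyphenyl compound from the 3,4-dimethoxyphenyl one. Against the 4-chlorophenyl compound, the same group gives a 1.2-fold higher number from compound 1 to compound 3 (0.08 log units; within the scatter) and so leaves all three aryl groups at this position within the scatter of one another. Nothing measured here offers an explanation for these values.

The compounds shown leave open whether an amine or a carboxylic acid on this ring, or a longer chain linking it to the aromatic nitrogen, would move the number beyond the scatter.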